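This account rests on a few compounds, and the source may have more. Where it says the series, first, only, none or still open, it means among the compounds named here.

In a functional assay on ileum (Cavia porcellus) for inhibition of cysteinyl leukotriene receptor (Homo sapiens) (on this read-out higher numbers stand for weaker inhibition and lower numbers for stronger inhibition), compound 1 `CCCc1c(OCCCOc2cccc(OCC(=O)O)c2)ccc(C(C)=O)c1O` gives 500 nM, and compound 2 `CCCc1c(OCCOCCOc2c(C(C)=O)ccc(OCC(=O)O)c2CCC)ccc(C(C)=O)c1O` gives 200 nM. Compound 2 thus holds the lowest of the two numbers, and its gap to compound 1 lies beyond the scatter. Compound 3 `CCCc1c(OCCOCCOc2c(C(C)=O)ccc(OCCCC(=O)O)c2CCC)ccc(C(C)=O)c1O` is the next step from compound 2, with 2-carboxyethyl in place of carboxy on a saturated chain carbon bound to an oxygen on an aromatic ring; the same change, read one bond further out, is carboxymethoxy becoming 3-carboxypropoxy. For the measured compounds named here, no measured pair shows the effect of such lengthening, so only a small shift is expected, close to the scatter, leaning toward a slightly higher number. The estimate for compound 3 is 300 nM, within 100 nM to 1000 nM, a step of a 1.5-fold higher number from compound 2 to compound 3 (0.18 log units; within the scatter) from compound 2.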

Compound 3, half-maximal inhibitory concentration: 100 nM
The estimate for compound 3 lay 3.0-fold (0.48 log units) above the measured number, within the range that was stated.
By their numbers in this assay, from the lowest: compounds 3 and 2 (each within the scatter of the next); then compound 1.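

In this assay, for the compounds shown here, this is the first change at this position: on a saturated chain carbon bound to an oxygen on an aromatic ring, 2-carboxyethyl in place of carboxy gives a 2.0-fold lower number from compound 2 to compound 3 (0.30 log units; within the scatter). Carboxymethoxy can therefore become 3-carboxypropoxy without the read-out separating from that of compound 2 beyond the scatter. No measurement here explains this result.

A single step cannot show how the read-out follows chain length at this position. From the compounds shown here alone, whether a longer chain, or an amide in place of the carboxylic acid, would shift the number beyond the scatter stays open.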